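Moving the trifluoromethoxy group on a sulfonyl aryl ring

The source may report more compounds than this note shows. Statements on the series, on what has been measured and on what is new or still open speak of the compounds shown alone.

compound 1 `CC(O)(CS(=O)(=O)c1ccc(C(F)(F)F)cc1)C(=O)Nc1ccc(S(F)(F)(F)(F)F)cc1` gives 27700 nM 
compound 2 `CC(O)(CS(=O)(=O)c1cccc(C(F)(F)F)c1)C(=O)Nc1ccc(S(F)(F)(F)(F)F)cc1` gives 32000 nM 
compound 3 `CC(O)(CS(=O)(=O)c1ccc(OC(F)(F)F)cc1)C(=O)Nc1ccc(S(F)(F)(F)(F)F)cc1` gives 95800 nM 

All three were tested in a functional assay on VCaP cells (Homo sapiens) for antiproliferative activity, read by propidium iodide staining, with a stated time of 96 h (on this read-out lower numbers stand for stronger inhibition and higher numbers for weaker inhibition), and share one core. Compound 3 has the highest number of the three, so it is the weakest so far (a 3.5-fold higher number from compound 1 to compound 3 (0.54 log units; beyond the scatter); a 3.0-fold higher number from compound 2 to compound 3 (0.48 log units; beyond the scatter)). Compound 4 `CC(O)(CS(=O)(=O)c1cccc(OC(F)(F)F)c1)C(=O)Nc1ccc(S(F)(F)(F)(F)F)cc1` carries 3-(trifluoromethoxy)phenyl in place of 4-(trifluoromethoxy)phenyl on a sulfonyl sulfur. For the measured compounds named here, the closest precedent is the same move made with trifluoromethyl (a 1.2-fold higher number from compound 1 to compound 2 (0.06 log units; within the scatter)), a single example that stayed within the scatter. The two larger steps involve a different change, so no shift beyond the scatter is expected here (a 1.1-fold lower number from compound 3 to compound 4 (0.03 log units; within the scatter)). For compound 4 the estimated value is 90000 nM with an expected range of 40000 nM to 190000 nM in this assay.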

Compound 4, half-maximal inhibitory concentration: 23700 nM
The estimate for compound 4 lay 3.8-fold (0.58 log units) above the measured number, outside the stated range (below it).
By their numbers in this assay, from the lowest: compounds 4, 1 and 2 (each within the scatter of the next); then compound 3.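

Here the ring position matters for trifluoromethoxy, with a 4.0-fold lower number from compound 3 to compound 4 (0.61 log units; beyond the scatter), although the same move with trifluoromethyl gave only a 1.2-fold higher number from compound 1 to compound 2 (0.06 log units; within the scatter). Compound 4 also falls level with both trifluoromethyl compounds, with a 1.4-fold lower number from compound 2 to compound 4 (0.13 log units; within the scatter) and a 1.2-fold lower number from compound 1 to compound 4 (0.07 log units; within the scatter), so compound 3 alone stands apart. Replacing trifluoromethyl with trifluoromethoxy therefore has no single effect, and the outcome depends on where the group sits: the same change on two cores in this assay, a 3.5-fold higher number (0.54 log units; beyond the scatter) from compound 1 to compound 3 and a 1.4-fold lower number (0.13 log units; within the scatter) from compound 2 to compound 4, 4.7-fold (0.67 log units) apart, beyond the scatter of two such steps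

The compounds shown leave open whether this dependence on ring position extends to groups without fluorine, such as methoxy or a nitrile.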